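Extending a methoxy group on a shared core

The compounds below may be only part of what the source reports. "The series", "measured", "known", "first", "only" and "open" are said of these compounds alone.

Measured so far:
Compound 1, `COc1ccc(-c2nc3cc(/C=C4\SC(=O)N(CC(=O)N5CCOCC5)C4=O)ccc3[nH]2)cc1OC`, gives 8930 nM in a functional assay on A549 cells (Homo sapiens) for inhibition, read by MTT assay, with a stated time of 48 h; a higher number here means a weaker inhibitor, a lower number a stronger inhibitor.
Compound 2, `COc1ccc(-c2nc3cc(/C=C4\SC(=O)N(Cc5cc(OC)c(OC)c(OC)c5)C4=O)ccc3[nH]2)cc1OC`, gives 130 nM in this assay.

Compound 2 stands at the lowest of the two numbers in this assay; its nearest neighbour is compound 1, and the step of a 69-fold lower number from compound 1 to compound 2 (1.84 log units; beyond the scatter) came from putting a 3,4,5-trimethoxyphenyl group in place of the morpholin-4-ylcarbonyl group on the chain carbon attached to the ring nitrogen of the shared core.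

Compound 3, `COc1cc(-c2nc3cc(/C=C4\SC(=O)N(Cc5cc(OC)c(OC)c(OC)c5)C4=O)ccc3[nH]2)ccc1OCC(C)C`, keeps everything that compound 2 has and changes only one spot on the other end of the molecule: isopropyl in place of hydrogen on a saturated chain carbon bound to an oxygen on an aromatic ring, so that a methoxy group becomes an isobutoxy group.

Within the data shown here, neither measured step touches this part of the structure; the single step from compound 1 to compound 2 concerns a different position and therefore gives no guidance on the size or direction of this change. With nothing to go on, the expectation for compound 3 is a step of a 1.2-fold higher number from compound 2 to compound 3 (0.06 log units; within the scatter), that is, no change beyond the scatter. Compound 3 is therefore estimated at 150 nM in this assay, with a range from 45 nM to 500 nM.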

Compound 3, half-maximal inhibitory concentration: 96 nM
The estimate for compound 3 lay 1.6-fold (0.19 log units) above the measured number, and the stated range covers the measured number.
By their numbers in this assay, from the lowest: compounds 3 and 2 (each within the scatter of the next); then compound 1.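

At the spot on a saturated chain carbon bound to an oxygen on an aromatic ring, turning methoxy into isobutoxy gives a 1.4-fold lower number from compound 2 to compound 3 (0.13 log units; within the scatter) in this assay, so compound 2 and compound 3 cannot be told apart by this measurement. Among these compounds, this is the first information about this part of the molecule: the earlier step, a 69-fold lower number from compound 1 to compound 2 (1.84 log units; beyond the scatter), concerned a different position, whereas here the isopropyl group adds 3 carbon atoms and the number stays within the scatter of the one set by compound 2. No measurement shown here explains why this addition makes so little difference.

A single step cannot show how far this tolerance extends, so the compounds shown leave open whether a longer chain such as octyl, or a chain ending in an amine or a carboxylic acid, would also keep the number in this range. They also leave open whether the same change from methoxy to isobutoxy would behave alike in a compound that carries the morpholin-4-ylcarbonyl group of compound 1 in place of the 3,4,5-trimethoxyphenyl group.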